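Methoxy placement on the phenoxy ring and acid dissociation

The source may hold more compounds than are shown below. What is called first, only, known or untested is meant among the compounds shown, and "the series" means these compounds.

compound 1: `COc1cccc(CNCCCNc2ccnc3cc(Oc4ccccc4)ccc23)c1O`, 9.28
compound 2: `COc1cccc(Oc2ccc3c(NCCCNCc4cccc(OC)c4O)ccnc3c2)c1`, 9.28

In a physicochemical assay for acid dissociation, compound 1 gives 9.28, and compound 2 gives 9.28. Within the data shown here, the single measured step, no change at the digits printed from compound 1 to compound 2 (within the scatter), puts compound 2 level with compound 1. Compound 3 (`COc1ccc(Oc2ccc3c(NCCCNCc4cccc(OC)c4O)ccnc3c2)cc1`) differs from compound 2 by 4-methoxyphenyl in place of 3-methoxyphenyl on an oxygen on an aromatic ring. Among the measured compounds shown here, only that one step bears on this change, and it left the value where it was, so no shift beyond the scatter is expected in this assay for compound 3, a step of no change at the digits printed from compound 2 to compound 3 (within the scatter). Compound 3 is therefore estimated at 9.28, within 8.98 to 9.58.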

Compound 3, acid dissociation constant: 9.28
The estimate for compound 3 equals the measured number at the digits printed; the measured number falls inside the stated range.
By their numbers in this assay, from the lowest: compounds 1, 2 and 3 (each within the scatter of the next).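

In this assay, the change of 3-methoxyphenyl to 4-methoxyphenyl on the oxygen gives no change at the digits printed from compound 2 to compound 3 (within the scatter), and methoxy in place of hydrogen, now in the 4-methoxyphenoxy arrangement, gives no change at the digits printed from compound 1 to compound 3 (within the scatter). Both methoxy placements shown therefore read level with compound 1, which compound 2 alone could not establish for more than one placement. Nothing available gives a reason for this result. Going by these compounds, whether an amine or a carboxylic acid in place of the methoxy, or a longer chain such as butoxy, would move the number beyond the scatter remains open.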